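The compounds below may be only part of what the source reports. "The series", "measured", "known", "first", "only" and "open" are said of these compounds alone.

Compound 2, `C=C(C)C(=O)Nc1cc2c(N3CCc4ccccc43)ncnc2cc1O[C@@H]1CCOC1`, stands at the higher end of the two numbers recorded so far. In a functional assay on A549 cells (Homo sapiens) for antiproliferative activity, read by MTT assay, with a stated time of 72 h (a higher number here means a weaker inhibitor, a lower number a stronger inhibitor), compound 2 gives 16600 nM, while compound 1, `C=C(C)C(=O)Nc1cc2c(N3CCc4ccccc43)ncnc2cc1OC`, gives 7320 nM. Going by the values given here, the one measured step, a 2.3-fold higher number from compound 1 to compound 2 (0.36 log units; beyond the scatter), concerns only the oxygen substituent on the aromatic ring, so compound 2 is the weaker of the pair on these numbers.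

Compound 3, `CCN(CC)C/C=C/C(=O)Nc1cc2c(N3CCc4ccccc43)ncnc2cc1O[C@@H]1CCOC1`, differs from compound 2 at a different place: 3-(diethylamino)prop-1-en-1-yl in place of 1-methylethenyl on a carbonyl carbon. Among the compounds with values here, no measured step touches the carbonyl side of the amide, so there is nothing in the data that directly bears on this change; the step from compound 1 to compound 2 tells only that the oxygen substituent is held constant between compound 2 and compound 3.

Within the data shown here, with no comparable step available, the expectation for compound 3 rests on the structural change alone, and the estimate is a modest move toward a lower number, a 2.4-fold lower number from compound 2 to compound 3 (0.38 log units; beyond the scatter), with a wide range. Compound 3 is therefore expected to give about 7000 nM in this assay, somewhere between 1500 nM and 30000 nM.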

Compound 3, half-maximal inhibitory concentration: 5220 nM
The estimate for compound 3 lay 1.3-fold (0.13 log units) above the measured number, within the range that was stated.
By their numbers in this assay, from the lowest: compounds 3 and 1 (each within the scatter of the next); then compound 2.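

The carbonyl side of the amide now has a measured step of its own: in this assay, with the oxolan-3-yl group on the oxygen held constant, 3-(diethylamino)prop-1-en-1-yl in place of 1-methylethenyl on the carbonyl carbon gives a 3.2-fold lower number from compound 2 to compound 3 (0.50 log units; beyond the scatter). This position, which the earlier pair left untouched, therefore responds in this assay, and the larger, nitrogen-bearing group goes with a stronger inhibitor than the group it replaces, although one step cannot separate the contribution of the added nitrogen from that of the added carbons. No measurement shown here explains why the number falls.

On these data alone, it remains open whether the same change would give a similar step with methyl on the oxygen, as in compound 1, since the 3-(diethylamino)prop-1-en-1-yl group appears here only with oxolan-3-yl. As far as these compounds go, it is also open how a different amine in place of the diethylamino part, such as dimethylamino or morpholine, or a chain with no amine at all, would read in this assay.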